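This account rests on a few compounds, and the source may have more. Where it says the series, first, only, none or still open, it means among the compounds named here.

Compound 1 `Nc1cc2ccccc2cc1NC(=O)c1ccc(CNc2nccc(-c3cccnc3)n2)cc1` was tested in an assay on isolated protein for inhibition of protein deacetylase HDAC6 (Homo sapiens), read by fluorescence, with stated times of 3 h and 60 min (a higher number here means a weaker inhibitor, a lower number a stronger inhibitor), where compound 1 gives > 20000 nM, which is a limit of the assay rather than a measured number. Two further compounds belong to the same set. Compound 3 `CC(=O)N1C(NCc2ccc(C(=O)Nc3ccccc3N)cc2)=NC(=O)C1Cc1c[nH]c2ccccc12` in this assay reaches only > 20000 nM, again a limit. Compound 2 `Nc1ccccc1NC(=O)c1ccc(CNC2=N[C@@H](c3ccc(O)cc3)CS2)cc1` has "not determined" (no result reported) in this assay. So compound 1 stands where the numbers run out: the limit of > 20000 nM in this assay, at which 2 of the 3 values shown sit, and no single figure separates any pair of these compounds from one another.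

Compound 4 `Nc1cc(Br)ccc1NC(=O)c1ccc(CNc2nccc(-c3cccnc3)n2)cc1` has not yet been measured. It differs from compound 1 in one place (a group of 8 heavy atoms (6 carbon, 1 nitrogen, 1 bromine; one six-membered aromatic ring of carbon only) in place of a group of 11 heavy atoms (10 carbon, 1 nitrogen; 2 six-membered aromatic rings of carbon only), on an amide-type nitrogen). Among the compounds with values here, with compound 1 at the limit and compound 3 at the same limit, there is no measured step to lean on. The step of a number no higher from compound 1 to compound 4 (the limit leaves the size open) is expected to be none beyond the usual scatter. Compound 4 is therefore estimated at 20000 nM, in a range from 8000 nM to 50000 nM, with a real chance that only a limit is reported again.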

Compound 4, half-maximal inhibitory concentration: > 20000 nM
Compound 4 ended at the assay's limit; the forecaster's own chance of this, stated with the estimate: 70%; the middle value sits exactly at the limit.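

Within the data shown here, compound 1 and compound 4 both stand at the limit of this assay, so no step between them can be read. The compounds shown leave open whether the 2-amino-4-bromophenyl group changes inhibition at all, because none gives a single number: the limit of > 20000 nM in this assay, at which 3 of the 4 values shown sit.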